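The compounds below may be only part of what the source reports. "The series", "measured", "known", "first", "only" and "open" are said of these compounds alone.

Of the compounds shown here, two of a shared series have been measured for how far they activate the receptor in an assay on cells for agonist activity at probable G-protein coupled receptor 34 (Mus musculus), with a stated time of 1 h; a higher number here means a larger maximal response, a lower number a smaller maximal response. Compound 1, `CCCCCCCCCCCOc1ccccc1CCC(=O)OCCCOP(=O)(O)OC[C@H](N)C(=O)O`, carries a long alkyl chain on the phenoxy part; in this assay compound 1 gives 14.6%. Compound 2, `Cc1ccccc1Oc1cccc(COc2ccccc2CCC(=O)OCCCOP(=O)(O)OC[C@H](N)C(=O)O)c1`, carries a 2-methylphenoxy group in place of that chain; in this assay compound 2 gives 20.3%. The two numbers lie within the usual scatter of each other, so the data do not separate compound 2 from compound 1, and both sit at a modest level of maximal response.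

Compound 3, `N[C@@H](COP(=O)(O)OCCCOC(=O)CCc1ccccc1OCc1cccc(Oc2ccc(Cl)c(Cl)c2)c1)C(=O)O`, is the next member. It differs from compound 2 in a single place: 3,4-dichlorophenyl in place of 2-methylphenyl on an oxygen on an aromatic ring. For the measured compounds named here, no measured pair shows what such a swap does, so there is no step to lean on.

Without such a step, the expectation is that the change from compound 2 to compound 3 is small, and the step of a number 1.7 percentage points higher from compound 2 to compound 3 (within the scatter) is estimated to stay within the scatter rather than point clearly in either direction. Compound 3 is accordingly expected to give about 22%, with a plausible range from 8% to 45%.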

Compound 3, largest response reached (Emax), in percent of the reference or control that the assay uses: 18%
Compound 3: the middle estimate sits 4 percentage points above what was measured, and the stated range covers the measured number.
By their numbers in this assay, from the lowest: compounds 1, 3 and 2 (each within the scatter of the next).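

Placing 3,4-dichlorophenyl in place of 2-methylphenyl on an oxygen on an aromatic ring gives, in this assay, a number 2.3 percentage points lower from compound 2 to compound 3 (within the scatter). For the compounds shown here, this is the first pair that differs in only one place, and it shows that this exchange of one carbon-only aromatic ring for another, with chlorine in place of the methyl group, leaves the maximal response indistinguishable from that of compound 2. Nothing measured here bears on the reason for this result.

A single exchange changes both the substituents on the ring and where they sit, so it cannot show what the methyl group or either chlorine contributes alone; phenyl without substituents or with a single chlorine would separate those parts. As far as these compounds go, it also remains open whether a ring carrying a different kind of group, such as an amine, a carboxylic acid or a nitrile, or a pyridine ring in place of the phenyl, would move the maximal response beyond the usual scatter.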